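A few compounds are considered here, and "the series" means these few. Any claim that something is new, unique, unknown or untested is made for them only; others in the source may bear on it.

Working notes on the series in an ADME assay on L6 cells (Rattus norvegicus) for cytotoxicity, read by resazurin assay, with a stated time of 72 h; on this read-out lower numbers stand for stronger inhibition and higher numbers for weaker inhibition. Compound 1 `Cc1occc1C(=O)NC(=O)c1ccccc1O` gives 16 ug/mL, compound 2 `CC(C)(C)c1ccc(C(=O)NC(=O)c2ccccc2O)cc1` gives 2.3 ug/mL and compound 3 `O=C(NC(=O)c1ccccc1O)c1ccc(OC(F)(F)F)cc1` gives 84 ug/mL. Compound 2 thus holds the lowest number of the three, with both gaps beyond the scatter. Compound 4 `N#Cc1ccc(C(=O)NC(=O)c2ccccc2O)cc1` carries cyano in place of tert-butyl on an aromatic carbon, para to a large group: cyano in place of tert-butyl on an aromatic carbon. Among the measured compounds shown here, the only measured step that replaces tert-butyl is the change to trifluoromethoxy, a 37-fold higher number from compound 2 to compound 3 (1.56 log units; beyond the scatter), which is large. One step is thin support, but a higher number of somewhat smaller size is expected here. The expected step is an 11-fold higher number from compound 2 to compound 4 (1.04 log units; beyond the scatter). For compound 4 the estimate is 25 ug/mL, with a range of 7 ug/mL to 85 ug/mL.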

Compound 4, half-maximal inhibitory concentration: 55 ug/mL
Compound 4: middle estimate off by 2.2-fold (0.34 log units), on the low side; the range from low to high includes it.
By their numbers in this assay, from the lowest: compound 2; then compound 1; then compounds 4 and 3 (each within the scatter of the next).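

At this position in this assay, a second replacement of tert-butyl also gives a higher number (a 24-fold higher number from compound 2 to compound 4 (1.38 log units; beyond the scatter)), so the low number of compound 2 no longer rests on the trifluoromethoxy step alone. Cyano and trifluoromethoxy cannot be told apart here (a 1.5-fold lower number from compound 3 to compound 4 (0.18 log units; within the scatter)). No measurement at hand gives a cause for these steps. Still open, from the compounds shown here alone, is whether an amine, a carboxylic acid or a methyl group at this place would give a number near that of compound 2 or near those of compounds 3 and 4.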